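This account rests on a few compounds, and the source may have more. Where it says the series, first, only, none or still open, it means among the compounds named here.

Three compounds share one backbone and were tested in a functional assay on MDA-MB-231 cells (Homo sapiens) for antiproliferative activity, with a stated time of 72 h; on this read-out higher numbers stand for an effect only at larger amounts of compound and lower numbers for an effect already at smaller amounts. Compound 1 `COC(=O)c1ccc(N(Cc2ccc(C3CCCCC3)cn2)C(=O)[C@H]2CCN2S(=O)(=O)c2c(F)c(F)c(F)c(F)c2F)cc1O` gives 1800 nM in this assay. Compound 2 `COC(=O)c1ccc(N(Cc2cnc(C3CCCCC3)cn2)C(=O)[C@H]2CCN2S(=O)(=O)c2c(F)c(F)c(F)c(F)c2F)cc1O` gives 1600 nM. Compound 3 `O=C([C@H]1CCN1S(=O)(=O)c1c(F)c(F)c(F)c(F)c1F)N(Cc1ccc(C2CCCCC2)cn1)c1ccc2c(=O)[nH]cnc2c1` gives 3300 nM, the highest of the three numbers, although its gap to compound 1 stays within the scatter.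

Compound 2 differs from compound 1 in one place: 5-cyclohexylpyrazin-2-yl in place of 5-cyclohexylpyridin-2-yl on a saturated chain carbon bound to an amide-type nitrogen. That change brought a 1.1-fold lower number from compound 1 to compound 2 (0.05 log units; within the scatter), so within the scatter the two compounds look alike.

Compound 3 differs from compound 1 in the group on the amide-type nitrogen: a group of 11 heavy atoms (8 carbon, 2 nitrogen, 1 oxygen; one six-membered aromatic ring of carbon only, one six-membered aromatic ring with 2 hetero atoms) in place of a group of 11 heavy atoms (8 carbon, 3 oxygen; one six-membered aromatic ring of carbon only), on an amide-type nitrogen. Here the step was a 1.8-fold higher number from compound 1 to compound 3 (0.26 log units; within the scatter).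

Compound 4 `O=C([C@H]1CCN1S(=O)(=O)c1c(F)c(F)c(F)c(F)c1F)N(Cc1cnc(C2CCCCC2)cn1)c1ccc2c(=O)[nH]cnc2c1` has not yet been measured. It carries the core of compound 3 and differs from it in exactly the same place and in the same way as compound 2 differs from compound 1: 5-cyclohexylpyrazin-2-yl in place of 5-cyclohexylpyridin-2-yl on a saturated chain carbon bound to an amide-type nitrogen. The place lines of the two changes read identically, so this is the same change made on a different core. One earlier example of this change exists, and it left the number essentially unchanged.

Resting on that single precedent, the step from compound 3 to compound 4 in this assay is expected to be a 1.1-fold lower number from compound 3 to compound 4 (0.04 log units; within the scatter), about as small as the step from compound 1 to compound 2. Compound 4 is therefore estimated at 3000 nM in this assay, with a likely range from 1500 nM to 6000 nM. Whether the shared behaviour of the two cores holds will be seen once compound 4 is measured.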

Compound 4, half-maximal effective concentration: 4200 nM
Compound 4: middle estimate off by 1.4-fold (0.15 log units), on the low side; low and high end bracket the measured number.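

In this assay, putting 5-cyclohexylpyrazin-2-yl in place of 5-cyclohexylpyridin-2-yl on the core of compound 3 gave a 1.3-fold higher number from compound 3 to compound 4 (0.10 log units; within the scatter), and this step agrees with the earlier one: the same change on two cores in this assay, a 1.1-fold lower number (0.05 log units; within the scatter) from compound 1 to compound 2 and a 1.3-fold higher number (0.10 log units; within the scatter) from compound 3 to compound 4, 1.4-fold (0.16 log units) apart, within the scatter of two such steps. The other change in the set, the exchange of the group on the amide-type nitrogen, can now also be read on a second pair, where it gave a 2.6-fold higher number from compound 2 to compound 4 (0.42 log units; beyond the scatter), and the two readings again agree: the same change on two cores in this assay, a 1.8-fold higher number (0.26 log units; within the scatter) from compound 1 to compound 3 and a 2.6-fold higher number (0.42 log units; beyond the scatter) from compound 2 to compound 4, 1.4-fold (0.16 log units) apart, within the scatter of two such steps. So on these two cores both changes carried over, but this rests on only two pairs in one assay, the pyrazinyl swap stayed within the scatter both times, and none of this shows that either change would behave the same way on any other core or in any other test.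

Going by these compounds, all four compounds keep the cyclohexyl ring, so it stays open what an open hexyl chain, a phenyl ring or an amine in its place would do to the number. The same question stands for the group on the amide-type nitrogen, where a carboxylic acid in place of the ester carbonyl group of compound 1 could show whether these small steps persist.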